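Trifluoromethyl on the Benzoate: Expected Cytotoxicity Shift

A few compounds are considered here, and "the series" means these few. Any claim that something is new, unique, unknown or untested is made for them only; others in the source may bear on it.

Compound 1 `CN(C)c1ccc(-c2cn(-c3ccnc4cc(Cl)ccc34)nn2)cc1` reaches only a limit in an ADME assay on HepG2 cells (Homo sapiens) for cytotoxicity, read by MTT assay, with a stated time of 24 h; on this read-out lower numbers stand for higher toxicity in this test and higher numbers for lower toxicity in this test: > 2860000 nM.
Compound 2 `COc1ccc2cc(-c3cn(-c4ccnc5cc(Cl)ccc45)nn3)ccc2c1` likewise gives a limit, > 2590000 nM.
Compound 3 `O=C(OCCCc1cn(-c2ccnc3cc(Cl)ccc23)nn1)c1ccccc1` gives 1200000 nM.

Within the data shown here, compound 3 therefore holds the only actual number among the three; the other two sit at limits rather than measured values. One of these limits is the limit of > 2590000 nM in this assay, at which 1 of the 3 values shown sits. The other is the limit of > 2860000 nM in this assay, at which 1 of the 3 values shown sits. Compound 4 `O=C(OCCCc1cn(-c2ccnc3cc(Cl)ccc23)nn1)c1ccc(C(F)(F)F)cc1` differs from compound 3 by trifluoromethyl in place of hydrogen on an aromatic carbon. Among the measured compounds shown here, no step between measured compounds is known, so this change cannot be placed against a measured precedent in this set. For compound 4 in this assay the expected step is small, a 1.3-fold lower number from compound 3 to compound 4 (0.12 log units; within the scatter), within the usual scatter, leaning only slightly toward greater toxicity. Compound 4 is accordingly estimated at 900000 nM, with a range from 300000 nM to 2500000 nM.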

Compound 4, half-maximal cytotoxic concentration: > 2170000 nM
Compound 4: no number, only a limit (the forecaster's own chance of this, stated with the estimate: 15%); middle value at least 2.4-fold (0.38 log units) away from the limit.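

In this assay compound 4 gives > 2170000 nM, which is a limit and not a number. Replacing hydrogen with trifluoromethyl on this aromatic carbon, para to a large group, gives an at least 1.8-fold higher number from compound 3 to compound 4 (0.25 log units; that floor lies within the scatter). This first measured step in the set shows that going from phenyl to 4-(trifluoromethyl)phenyl does not move the result toward greater toxicity in this test.

Going by these compounds, the true size of the step stays open. Also open, on these data alone, is what an amine or a carboxylic acid at this position, or a longer chain leading to the benzoate, would do.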